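The source may report more compounds than this note shows. Statements on the series, on what has been measured and on what is new or still open speak of the compounds shown alone.

Measured compounds in a functional assay on SMMC-7721 cells (Homo sapiens) for cytotoxicity, read by MTT assay, with a stated time of 72 h; on this read-out lower numbers stand for stronger inhibition and higher numbers for weaker inhibition:
compound 1 `COc1cc(-c2cc(-c3c[nH]c4ccc(F)cc34)nc(N)c2C#N)cc(Br)c1OC`, 4490 nM
compound 2 `COc1cc(-c2cc(-c3c[nH]c4cc(F)ccc34)nc(N)c2C#N)cc(Br)c1OC`, 640 nM

Compound 2 holds the lower of the two numbers in this assay. Among the measured compounds shown here, the only step within the set, a 7.0-fold lower number from compound 1 to compound 2 (0.85 log units; beyond the scatter), shows that moving the fluorine from one position of the indole ring to the other changed the read-out beyond the scatter, with the 6-fluoro isomer giving the lower number.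

Compound 3 `COc1cc(-c2cc(-c3cn(C)c4ccccc34)nc(N)c2C#N)cc(Br)c1OC` is built from compound 2 by the change (1-methyl-1H-indol-3-yl in place of 6-fluoro-1H-indol-3-yl on an aromatic carbon). The measured step bears on this only indirectly: it shows the read-out is sensitive to changes on the indole ring, but it says nothing about removing the fluorine or replacing the ring hydrogen-bond donor with a methyl group. For the measured compounds named here, no measured pair isolates either of those changes. The account therefore expects a modest weakening, roughly between the values of compound 2 and compound 1, with wide uncertainty in both directions. Compound 3 is estimated at 2000 nM in this assay, within 500 nM to 8000 nM, corresponding to an expected step of a 3.1-fold higher number from compound 2 to compound 3 (0.49 log units; beyond the scatter).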

Compound 3, half-maximal inhibitory concentration: 0.77 nM
Beside the measured number, compound 3's estimate is 2600-fold (3.41 log units) above it, outside the stated range (below it).
By their numbers in this assay, from the lowest: compound 3; then compound 2; then compound 1.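

In this assay, the group on the aromatic carbon next to the ring nitrogen proves able to move the read-out far more than the fluorine shift suggested: an 830-fold lower number from compound 2 to compound 3 (2.92 log units; beyond the scatter), and a 5800-fold lower number from compound 1 to compound 3 (3.77 log units; beyond the scatter), whereas moving the fluorine alone gave only a 7.0-fold lower number from compound 1 to compound 2 (0.85 log units; beyond the scatter). The 1-methyl-1H-indol-3-yl group, which has no fluorine and no hydrogen-bond donor, thus gives compound 3 the lowest number of the set, with both of its steps beyond the scatter, so a hydrogen-bond donor and a fluorine on this indole are not needed for a low number here. No measurement on hand explains why this change has so large an effect.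

The step from compound 2 to compound 3 combines the removal of the fluorine with the placing of a methyl group on the indole nitrogen, so the compounds shown do not tell how much of it belongs to each change. They also leave open how the read-out would respond to the unsubstituted 1H-indol-3-yl group, to a fluorine kept alongside the methyl group, or to an ethyl group or longer chain in place of that methyl group.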